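The compounds below may be only part of what the source reports. "The series", "measured", "known", "first", "only" and "open" are said of these compounds alone.

Measured so far:
compound 1 `Nc1nc(O)c2c(n1)n(C1OC(CO)[C@@H](O)[C@H]1O)c(=O)n2Cc1ccc(Cl)cc1`; in a functional assay (B cells) with Mus musculus as the target (on this read-out higher numbers stand for an effect only at larger amounts of compound and lower numbers for an effect already at smaller amounts), compound 1 gives 14 uM
compound 2 `C=CCSc1nc2c(O)nc(N)nc2n1C1OC(CO)[C@@H](O)[C@H]1O`; in this assay compound 2 gives 107 uM

Compound 1 holds the lower of the two numbers, and compound 2 lies beyond the scatter from it; the two share no single-point difference, so only their values can be set side by side. Compound 3 `Nc1nc(O)c2c(n1)n(C1OC(CO)[C@@H](O)[C@H]1O)c(=O)n2C/C=C/c1ccccc1` is not yet measured. It differs from compound 1 by 2-phenylethenyl in place of 4-chlorophenyl on a saturated chain carbon bound to an aromatic nitrogen. Going by the values given here, no measured pair shows a change of this kind, so the step of a 1.4-fold higher number from compound 1 to compound 3 (0.15 log units; within the scatter) is expected to stay within the scatter, if anything toward a higher number. Compound 3 is estimated at 20 uM, with a range from 7 uM to 60 uM.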

Compound 3, concentration for half-maximal effect: 103 uM
The estimate for compound 3 lay 5.2-fold (0.71 log units) below the measured number; measured number above the stated range.
By their numbers in this assay, from the lowest: compound 1; then compounds 3 and 2 (each within the scatter of the next).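

Going by these compounds alone, with 2-phenylethenyl in place of 4-chlorophenyl, the series shows a 7.4-fold higher number from compound 1 to compound 3 (0.87 log units; beyond the scatter) in this assay and so gives the first evidence that this position, on a saturated chain carbon bound to an aromatic nitrogen, responds to substitution. The change removes the chlorine and adds a double bond outside aromatic rings, and this single step cannot separate the two. Nothing available explains the size of the step.

Open, on these data alone, is whether unsubstituted benzyl would stay with compound 1 or compound 3. A saturated 3-phenylpropyl chain at this position would test the double bond alone.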